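A few compounds are considered here, and "the series" means these few. Any claim that something is new, unique, unknown or untested is made for them only; others in the source may bear on it.

Compound 1 `COc1ccc(-c2nc(C)c(C(=O)CSc3nc(N)c(C#N)c(-c4ccc(Cl)cc4)n3)s2)cc1` and compound 2 `COc1ccc(-c2nc(C)c(C(=O)CSc3nc(N)c(C#N)c(-c4ccccc4)n3)s2)cc1` are built on the same core and differ in a single place. In a functional assay on U-87MG ATCC cells for antiproliferative activity against U-87 MG (Homo sapiens), read by MTT assay, with a stated time of 48 h, tested at 100 uM (a lower number here means a stronger effect, a higher number a weaker effect of the compound at the concentration tested), compound 1 gives 3.9%, while compound 2 gives 5.25%. The difference between them is hydrogen in place of chloro on an aromatic carbon and the measured step is a number 1.4 percentage points higher from compound 1 to compound 2 (within the scatter), so both readings say essentially the same thing about this pair.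

Compound 3 `Cc1nc(-c2ccc(Cl)cc2)sc1C(=O)CSc1nc(-c2ccc(Cl)c(Cl)c2)c(C#N)c(=O)[nH]1` rests on a different core; the difference between the core of compound 1 and the core of compound 3 is not broken down here. In this assay compound 3 gives 36.5%, the highest of the three numbers, and its distance from both compound 1 and compound 2 lies beyond the scatter.

Compound 4 `Cc1nc(-c2ccc(Cl)cc2)sc1C(=O)CSc1nc(-c2cccc(Cl)c2)c(C#N)c(=O)[nH]1` has not yet been measured. It differs from compound 3 by hydrogen in place of chloro on an aromatic carbon. Going by the values given here, this is the same kind of change as the one from compound 1 to compound 2, but not the same: in compound 3 the carbon that loses its chloro group is ortho to a chloro group and para to a large group, whereas in compound 1 it is only para to a large group. For compound 4 the step expected is a number 0.5 percentage points lower from compound 3 to compound 4 (within the scatter), because the step of a number 1.4 percentage points higher from compound 1 to compound 2 (within the scatter) stayed within the scatter when the same kind of change was made. Compound 4 is therefore expected to give about 36%, most likely somewhere between 22% and 50%.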

Compound 4, a percentage reported as activity, at one concentration (the size of the read-out at that concentration, not a potency): 12.5%
The estimate for compound 4 lay 23.5 percentage points above the measured number, outside the stated range (below it).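

This hydrogen-for-chloro change does not behave the same way on the two cores. In this assay, the change from 3,4-dichlorophenyl to 3-chlorophenyl gives a number 24 percentage points lower from compound 3 to compound 4 (beyond the scatter), a stronger effect at the concentration tested, so the near-silent result on the core of compound 1 cannot be assumed to carry over to the core of compound 3: the same change on two cores in this assay, a number 1.4 percentage points higher (within the scatter) from compound 1 to compound 2 and a number 24 percentage points lower (beyond the scatter) from compound 3 to compound 4, 25.4 percentage points apart, beyond the scatter of two such steps

Going by these compounds alone, this rests on only one pair per core, and the two pairs differ in more than the core, since the carbon that loses its chloro group in compound 3 is ortho to a chloro group, and compound 4 keeps that second chloro group on the ring. The data therefore cannot say whether the core or this local arrangement separates the two results, and a single-concentration read-out gives no potency and no reason for the gap.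

From the compounds shown here alone, it remains open whether a 3,4-dichlorophenyl group on the core of compound 1 would respond as compound 3 does, which would help separate those two explanations. Also open, going by these compounds, is whether the stronger effect depends on hydrogen itself or would also appear with another group at that carbon, such as a fluoro group or an amine.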